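Methoxy in place of hydrogen on the aryl of compound 1

The source may hold more compounds than are shown below. What is called first, only, known or untested is meant among the compounds shown, and "the series" means these compounds.

Two members of the series have numbers in a functional assay on cells for positive allosteric modulation of G-protein coupled receptor 68 (Homo sapiens), read by a luciferase reporter and cAMP accumulation, with a stated time of 30 min, at pH 6.8 and pH 8.3, in the presence of a further agent that is not named here (a higher number here means a more potent compound, by a factor of ten per unit of this negative logarithm, a lower number a less potent compound), so far. Compound 1 `Nc1nc(NCc2ccccc2)nc(-c2ccccc2CO)n1` gives 4.35 in this assay, the lowest of the two numbers. Its nearest neighbour is compound 2 `Nc1nc(NCc2ccccc2)nc(-c2cc(F)ccc2CO)n1`, which in this assay gives 4.58. Among the compounds with values here, the one step connecting them, a number 0.23 log units higher from compound 1 to compound 2 (within the scatter), is a fluoro in place of hydrogen on an aromatic carbon and stays within the scatter, so the two values cannot be ordered.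

The next compound is compound 3 `COc1cccc(CO)c1-c1nc(N)nc(NCc2ccccc2)n1`. It differs from compound 1 by methoxy in place of hydrogen on an aromatic carbon. Within the data shown here, the only measured step that touches the same ring, the fluoro step from compound 1 to compound 2, was small, and no step with a methoxy has been measured at all, so there is no basis for expecting a shift beyond the scatter in this assay in either direction. The step expected from this change is therefore a number 0.05 log units higher from compound 1 to compound 3 (within the scatter). Compound 3 is estimated at 4.4 in this assay, within a range from 3.9 to 4.9.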

Compound 3, negative logarithm of the antagonist equilibrium constant: "not active" (no number reported)
Compound 3 has no reported number here; there is nothing to compare the estimate with.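

Within the data shown here, compound 3 is reported as not active in this assay with no number, so no step from compound 1 to compound 3 can be read. Nothing shown offers an explanation for this result. The compounds shown leave open how far a methoxy in place of hydrogen on this ring moves the number, and in which direction.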